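Phenylsulfonyl gives way to benzyl in compound 3

This account rests on a few compounds, and the source may have more. Where it says the series, first, only, none or still open, it means among the compounds named here.

Values so far in an ADME assay on Huh-7 cells (Homo sapiens) for cytotoxicity, read by XTT assay (a higher number here means that more compound is tolerated, a lower number that less compound is tolerated), for two compounds
- compound 1 `CC(C)(C)C(=O)OC[C@H]1O[C@@H](n2cnc3c(Cl)ncnc32)C[C@@H]1O` with 177000 nM
- compound 2 `O=S(=O)(OC[C@H]1O[C@@H](n2cnc3c(Cl)ncnc32)C[C@@H]1O)c1ccccc1` with 146000 nM

Compound 2 (146000 nM) stands level with compound 1 within the scatter, and these two numbers are the only ones available so far. The next compound, compound 3 `O[C@H]1C[C@H](n2cnc3c(Cl)ncnc32)O[C@@H]1COCc1ccccc1`, keeps the shared core and carries benzyl in place of phenylsulfonyl on an oxygen on a saturated carbon. Going by the values given here, one measured step bears on this change, as it concerns the same oxygen. It is a 1.2-fold lower number from compound 1 to compound 2 (0.08 log units; within the scatter) and sets phenylsulfonyl in place of (tert-butyl)carbonyl. Among the compounds with values here, two different groups at this place have therefore given numbers that cannot be told apart, although no measured compound carries benzyl, so the evidence is thin. Going by that step from compound 1 to compound 2 (a 1.2-fold lower number from compound 1 to compound 2 (0.08 log units; within the scatter)), no change beyond the scatter is expected in this assay. The expected change is small, an estimated 1.1-fold lower number from compound 2 to compound 3 (0.05 log units; within the scatter) with no firm direction. For compound 3 the estimated value is 130000 nM with an expected range from 55000 nM to 300000 nM in this estimate.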

Compound 3, half-maximal cytotoxic concentration: 178000 nM
For compound 3 the middle estimate is 1.4-fold (0.14 log units) below the measured one, and the stated range covers the measured number.
By their numbers in this assay, from the lowest: compounds 2, 1 and 3 (each within the scatter of the next).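

In this assay, benzyl in place of phenylsulfonyl gives a 1.2-fold higher number from compound 2 to compound 3 (0.09 log units; within the scatter), and benzyl in place of (tert-butyl)carbonyl gives a 1.0-fold higher number from compound 1 to compound 3 (0.00 log units; within the scatter). Three different groups on this oxygen on a saturated carbon now give numbers that cannot be told apart, which extends what the first pair showed to a group made of carbon only: phenylsulfonyl brings 2 hydrogen-bond acceptors and sulfur, while benzyl brings 0 hydrogen-bond acceptors and only carbon. Nothing shown here accounts for this level reading at the position, so it stands as an observation on these three compounds alone.

From the compounds shown here alone, all three compounds keep the shared core and a bulky, uncharged group on this oxygen, so it remains open whether a group carrying an amine or a carboxylic acid, a longer chain, or a bare hydrogen in this place would also stay level with them. Going by these compounds, it also remains open whether the same level reading would hold in a cell line other than the one used here, or with the chlorine of the shared core replaced.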